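Replacing 4-methylbenzyl with 4-methoxyphenyl on an amide-type nitrogen

The compounds below may be only part of what the source reports. "The series", "measured", "known", "first", "only" and "open" are said of these compounds alone.

In a functional assay on LoVo cells (Homo sapiens) for inhibition, read by MTT assay, with a stated time of 72 h (on this read-out higher numbers stand for weaker inhibition and lower numbers for stronger inhibition), compound 1 (`C=C(Br)C(=O)Nc1cccc(/C=C/C(=O)Nc2ccc(Cl)cc2)c1`) gives 5900 nM and compound 2 (`C=C(Br)C(=O)Nc1cccc(/C=C/C(=O)NCc2ccc(C)cc2)c1`) gives 1900 nM, so compound 2 holds the lower of the two numbers and shows the stronger inhibition so far. Among the measured compounds shown here, the single measured step, a 3.1-fold lower number from compound 1 to compound 2 (0.49 log units; beyond the scatter), put 4-methylbenzyl in place of 4-chlorophenyl on an amide-type nitrogen.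

Compound 3 (`C=C(Br)C(=O)Nc1cccc(/C=C/C(=O)Nc2ccc(OC)cc2)c1`) changes that same place: 4-methoxyphenyl in place of 4-methylbenzyl on an amide-type nitrogen. Like compound 1, it carries a substituted phenyl group there rather than a substituted benzyl group, so the one measured step bears on this change in reverse. The match is only partial, since 4-methoxyphenyl is not 4-chlorophenyl, and the data hold no measurement of the 4-methoxyphenyl group. A higher number is therefore expected in this assay, similar to or somewhat smaller than the size of the reverse of a 3.1-fold lower number from compound 1 to compound 2 (0.49 log units; beyond the scatter). The expected change is a 2.0-fold higher number from compound 2 to compound 3 (0.30 log units; within the scatter). For compound 3 the estimated value is 3800 nM, with an expected range from 1500 nM to 9500 nM.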

Compound 3, half-maximal inhibitory concentration: 550 nM
For compound 3 the middle estimate is 6.9-fold (0.84 log units) above the measured one; measured number outside the range, below it.
By their numbers in this assay, from the lowest: compound 3; then compound 2; then compound 1.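

In this assay, the order of the compounds is not set by the choice between a phenyl and a benzyl group alone, as the earlier pair might have suggested. With both compounds carrying a substituted phenyl group on the amide-type nitrogen, methoxy in place of chloro on an aromatic carbon gives an 11-fold lower number from compound 1 to compound 3 (1.03 log units; beyond the scatter), the largest step shown, so the substituent on that ring counts for a great deal here; 4-methoxyphenyl in place of 4-methylbenzyl then gives a 3.5-fold lower number from compound 2 to compound 3 (0.54 log units; beyond the scatter), which puts one phenyl compound on each side of the benzyl compound 2 and makes compound 3, not compound 1, the one that goes against any rule favouring benzyl. The entering group also counts one hydrogen-bond acceptor where 4-methylbenzyl counts none, but no evidence at hand links this or any other feature to the differences in these numbers.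

The compounds shown leave open how a 4-methoxybenzyl group would compare, which would separate the effect of the methoxy group from that of the extra carbon in the benzyl group. They also leave open whether the gain is particular to methoxy or would carry over to a longer ether such as ethoxy, or to a hydroxyl or a dimethylamino group at that ring position.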